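A few compounds are considered here, and "the series" means these few. Any claim that something is new, unique, unknown or untested is made for them only; others in the source may bear on it.

Compound 1 `Cc1cc(NS(=O)(=O)c2ccc(N3C(=O)/C(=C/c4coc5ccccc5c4=O)N=C3c3ccc(Cl)cc3)cc2)no1` opens this account. In a functional assay on A549 cells (Homo sapiens) for cytotoxicity, read by sulforhodamine B assay, with a stated time of 72 h (on this read-out higher numbers stand for weaker inhibition and lower numbers for stronger inhibition), compound 1 gives only a limit, > 100000 nM, and the limit of > 100000 nM in this assay, at which 1 of the 3 values shown sits, is all that the measurement reveals of it. Two further compounds built around the same core give actual numbers. Compound 2 `O=C1/C(=C/c2coc3ccccc3c2=O)N=C(c2ccccc2)N1c1ccc(S(=O)(=O)Nc2nccs2)cc1` gives 88400 nM in this assay, and compound 3 `NS(=O)(=O)c1ccc(NC2=NC(=O)/C(=C\c3coc4ccccc4c3=O)S2)cc1`, which carries a free sulfonamide and a different five-membered core, gives 2230 nM. Compound 1 thus stands at the weak end of what has been measured, no stronger than either companion, and its place is known only as a limit rather than a value.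

The compound still to be measured, compound 4 `Cc1cc(C)nc(NS(=O)(=O)c2ccc(N3C(=O)/C(=C/c4coc5ccccc5c4=O)N=C3c3ccc(Cl)cc3)cc2)n1`, differs from compound 1 in a single place: 4,6-dimethylpyrimidin-2-yl in place of 5-methyl-1,2-oxazol-3-yl on a sulfonamide nitrogen. Going by the values given here, no measured pair records this change on this core, so its effect can only be guessed from the neighbours. Since compound 2, which carries yet another heterocycle on the same sulfonamide nitrogen, itself sits at the weak end with 88400 nM, the expected step that the limit leaves unreadable from compound 1 to compound 4 is one of no size beyond the usual scatter. Compound 4 is therefore estimated at 150000 nM, within a range of 50000 nM to 500000 nM, with a real chance that this assay again reports only a limit.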

Compound 4, half-maximal inhibitory concentration: 52600 nM
For compound 4 the middle estimate is 2.9-fold (0.46 log units) above the measured one, and the stated range covers the measured number.
By their numbers in this assay, from the lowest: compound 3; then compounds 4 and 2 (each within the scatter of the next). At a limit, above all of these: compound 1.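

Compound 1 is held at a limit in this assay, > 100000 nM, and so it offered no number to compare against. Placing 4,6-dimethylpyrimidin-2-yl in place of 5-methyl-1,2-oxazol-3-yl on a sulfonamide nitrogen gives an at least 1.9-fold lower number from compound 1 to compound 4 (0.27 log units; that floor lies within the scatter), so this pair is the first on the shared core to show that a change at this place can yield a readable number, although the printed floor of the step does not establish a real gain. The true size of the step stays unknown because one end of the pair is not a number: the limit of > 100000 nM in this assay, at which 1 of the 4 values shown sits.

The compounds shown do not tell how a pyridin-2-yl ring or a plain methyl on the same sulfonamide nitrogen would read on the core of compound 4, so it remains open whether the ring on that nitrogen matters at all. On these data alone, it is also open what an unsubstituted sulfonamide, as carried by compound 3, would give on the core of compound 4, since compound 3 differs from it in more than one place.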